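A few compounds are considered here, and "the series" means these few. Any claim that something is new, unique, unknown or untested is made for them only; others in the source may bear on it.

Compound 1 `CC(c1cc2cccnc2cc1F)n1cnc2ncc(-c3cn[nH]c3)nc21`: in a functional assay on NCI-H1993 cells (Homo sapiens) for inhibition, read by CCK-8 assay, with a stated time of 72 h (on this read-out higher numbers stand for weaker inhibition and lower numbers for stronger inhibition), compound 1 gives 187 nM
Compound 2 `Cc1c(C(C)n2cnc3ncc(-c4cn[nH]c4)nc32)ccc2ncccc12`: in this assay compound 2 gives 599 nM
Compound 3 `CC(c1cc2cccnc2cc1F)n1cnc2ncc(-c3cnn(CCO)c3)nc21`: in this assay compound 3 gives 175 nM

Compound 2 carries the highest of the three numbers; its nearest neighbour is compound 1, and the gap to compound 1, like that to compound 3, lies beyond the usual scatter. The difference between the core of compound 1 and the core of compound 2 is not broken down here.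

Compound 1 and compound 3 differ by 2-hydroxyethyl in place of hydrogen on an aromatic nitrogen. That change made a 1.1-fold lower number from compound 1 to compound 3 (0.03 log units; within the scatter), a step that falls within the scatter.

Compound 4 `Cc1c(C(C)n2cnc3ncc(-c4cnn(CCO)c4)nc32)ccc2ncccc12` has not yet been measured in this assay. It differs from compound 2 by 2-hydroxyethyl in place of hydrogen on an aromatic nitrogen, the same change, at a place described in the same words as for the pair of compound 1 and compound 3. For the measured compounds named here, the step is expected to be a 1.1-fold lower number from compound 2 to compound 4 (0.03 log units; within the scatter), resting on a 1.1-fold lower number from compound 1 to compound 3 (0.03 log units; within the scatter) as the only measured instance of this change. On that basis compound 4 is estimated at 560 nM, with a likely range from 280 nM to 1100 nM.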

Compound 4, half-maximal inhibitory concentration: 726 nM
For compound 4 the middle estimate is 1.3-fold (0.11 log units) below the measured one, within the range that was stated.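

Replacing 1H-pyrazol-4-yl with 1-(2-hydroxyethyl)-1H-pyrazol-4-yl on the core of compound 2 gives a 1.2-fold higher number from compound 2 to compound 4 (0.08 log units; within the scatter) in this assay, and the two steps agree: the same change on two cores in this assay, a 1.1-fold lower number (0.03 log units; within the scatter) from compound 1 to compound 3 and a 1.2-fold higher number (0.08 log units; within the scatter) from compound 2 to compound 4, 1.3-fold (0.11 log units) apart, within the scatter of two such steps

In this series, then, the change carried from one core to the other without a step beyond the scatter on either, so the measured effect of the 2-hydroxyethyl group on the first core was a fair guide to its effect on the second. This does not show that the group has a real effect in either direction, and two cores in one cell assay cannot establish that the same would hold on any other core.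

The compounds shown leave open whether a longer chain, such as 3-hydroxypropyl, or a chain ending in an amine or a carboxylic acid, on the same aromatic nitrogen would also leave the number within the scatter. They also leave open whether a simple methyl group there would behave like 2-hydroxyethyl on these two cores.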